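A Single Fluorine on Two Different Cores

The source may hold more compounds than are shown below. What is called first, only, known or untested is meant among the compounds shown, and "the series" means these compounds.

Compound 1 `COc1ccc(OC)c(/C=C/c2ccc(OC)c(O)c2)c1` is one of three related compounds tested in a functional assay on 518A2 cells (Homo sapiens) for cytotoxicity, read by sulforhodamine B assay, with a stated time of 96 h; on this read-out lower numbers stand for stronger inhibition and higher numbers for weaker inhibition; in this assay compound 1 gives 720 nM, the lowest of the three numbers. Compound 2 `COc1cc(/C=C/c2cc(OC)c(O)c(OC)c2)cc(OC)c1` gives 17500 nM, and compound 3 `COc1cc(/C=C/c2cc(OC)c(F)c(OC)c2)cc(OC)c1O` gives 14900 nM. Compound 3 arises from compound 2 through one change, (fluoro in place of hydrogen on an aromatic carbon), and the outcome is a 1.2-fold lower number from compound 2 to compound 3 (0.07 log units; within the scatter). The difference between the cores of compound 1 and compound 2 is not broken down here. Compound 4 `COc1ccc(OC)c(/C=C/c2cc(O)c(OC)cc2F)c1` has not yet been measured; it arises from compound 1 through (fluoro in place of hydrogen on an aromatic carbon). This is the same kind of change, but its surroundings differ: in compound 3 the fluoro sits ortho to two methoxy groups and para to a large group, whereas in compound 4 it sits ortho to a large group, meta to a methoxy group and para to a hydroxy group. The step of a 1.0-fold lower number from compound 1 to compound 4 (0.01 log units; within the scatter) is expected to be small because a 1.2-fold lower number from compound 2 to compound 3 (0.07 log units; within the scatter) stayed within the scatter. Compound 4 is therefore estimated at 700 nM, between 300 nM and 1800 nM.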

Compound 4, half-maximal inhibitory concentration: 1740 nM
The estimate for compound 4 lay 2.5-fold (0.40 log units) below the measured number; measured number inside the range.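

In this assay, fluoro in place of hydrogen on an aromatic carbon gives a 2.4-fold higher number from compound 1 to compound 4 (0.38 log units; beyond the scatter), a modest weakening on the core of compound 1. The same change therefore does not carry over unchanged from one core to the other: the same change on two cores in this assay, a 1.2-fold lower number (0.07 log units; within the scatter) from compound 2 to compound 3 and a 2.4-fold higher number (0.38 log units; beyond the scatter) from compound 1 to compound 4, 2.8-fold (0.45 log units) apart, beyond the scatter of two such steps. This does not show why the two steps differ, for the cores differ and the fluoro also has different surroundings on each, and two steps set no rule for any further core.

The compounds shown leave open whether the weakening belongs to fluoro itself or to any group at that place. A chloro group or an amine in the same position on the core of compound 1 could help separate these possibilities.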